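The source may report more compounds than this note shows. Statements on the series, on what has been measured and on what is new or still open speak of the compounds shown alone.

Of the compounds shown here, three that share one core have been measured in a functional assay on LN-229 cells (Homo sapiens) for antiproliferative activity, with a stated time of 72 h; on this read-out higher numbers stand for weaker inhibition and lower numbers for stronger inhibition. Compound 1 `Nc1ncnn2c([C@@H]3O[C@H](CO)[C@@H](O)[C@H]3O)cc(C#CC3CC3)c12`, which carries 2-cyclopropylethynyl, gives 30 nM. Compound 2 `Nc1ncnn2c([C@@H]3O[C@H](CO)[C@@H](O)[C@H]3O)cc(C#Cc3ccccc3)c12`, which carries 2-phenylethynyl, gives 88000 nM, and compound 3 `Nc1ncnn2c([C@@H]3O[C@H](CO)[C@@H](O)[C@H]3O)cc(-c3ccccc3)c12`, which carries phenyl, gives 75100 nM. Compound 3 thus stands second highest of the three numbers: it sits close to compound 2 and far above compound 1, as the steps of a 2500-fold higher number from compound 1 to compound 3 (3.40 log units; beyond the scatter) and a 1.2-fold lower number from compound 2 to compound 3 (0.07 log units; within the scatter) show.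

Compound 4 `Nc1ncnn2c([C@@H]3O[C@H](CO)[C@@H](O)[C@H]3O)cc(-c3ccc(F)cc3F)c12` is the compound still to be measured. It differs from compound 3 in one place: 2,4-difluorophenyl in place of phenyl on an aromatic carbon.

Among the measured compounds shown here, no measured step involves fluorine. For the measured compounds named here, the steps that bear on the question are a 2900-fold higher number from compound 1 to compound 2 (3.47 log units; beyond the scatter) and a 2500-fold higher number from compound 1 to compound 3 (3.40 log units; beyond the scatter), which show that exchanging the cyclopropyl-bearing group for an aromatic one raised the number greatly, and a 1.2-fold lower number from compound 2 to compound 3 (0.07 log units; within the scatter), which shows that two different aromatic groups gave numbers within the scatter of each other. Adding fluorines to the phenyl is a smaller change than either of those exchanges, so compound 4 is expected to stay near compound 3, with an estimated step of a 1.1-fold lower number from compound 3 to compound 4 (0.03 log units; within the scatter) that does not go beyond the scatter. The expected value for compound 4 in this assay is 70000 nM, with a range from 20000 nM to 200000 nM.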

Compound 4, half-maximal inhibitory concentration: 43500 nM
Beside the measured number, compound 4's estimate is 1.6-fold (0.21 log units) above it; the measured number falls inside the stated range.
By their numbers in this assay, from the lowest: compound 1; then compounds 4, 3 and 2 (each within the scatter of the next, the first and the last beyond it).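

Among the compounds shown here, this is the first substituted phenyl at this aromatic carbon of the five-membered ring, and in this assay exchanging phenyl for 2,4-difluorophenyl leaves the number within the usual scatter (a 1.7-fold lower number from compound 3 to compound 4 (0.24 log units; within the scatter)). Set against the 2-phenylethynyl group of compound 2, the same 2,4-difluorophenyl group gives a modest step that lies just beyond the scatter (a 2.0-fold lower number from compound 2 to compound 4 (0.31 log units; beyond the scatter)). The gap to the 2-cyclopropylethynyl group remains large (a 1500-fold higher number from compound 1 to compound 4 (3.16 log units; beyond the scatter)), so among these compounds, putting fluorines on the phenyl does not bring the number anywhere near that of compound 1.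

Going by these compounds, how a 4-aminophenyl group, a 4-carboxyphenyl group or a straight-chain alkyne such as 1-hexynyl would read at this same carbon stays open, as does whether a single fluorine on the phenyl would give a number like that of compound 4. Nothing available here explains why the 2-cyclopropylethynyl group stands so far from the aromatic groups, or why the fluorines change so little.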